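The compounds below may be only part of what the source reports. "The series", "measured", "known", "first", "only" and "open" are said of these compounds alone.

In a functional assay on THP-1 cells (Homo sapiens) for inhibition, read by luminescence, with a stated time of 72 h, tested at 5 uM (on this read-out higher numbers stand for more inhibition of growth at the one concentration tested and lower numbers for less inhibition of growth), compound 1 (`C=CS(=O)(=O)NC/C=C/c1cc(OC)cc(O)c1C(=O)OCc1ccc(Br)cc1`) gives 31.2% and compound 2 (`C=CS(=O)(=O)NC/C=C/c1cc(OC)cc(O)c1C(=O)OCC(C)c1ccccc1`) gives 5.6% as the lower of the two numbers. Compound 3 (`COc1cc(O)c(C(=O)OCC(C)c2ccccc2)c(/C=C/CN2C(=O)C=CC2=O)c1`) differs from compound 2 by one change (a group of 7 heavy atoms (4 carbon, 1 nitrogen, 2 oxygen; one five-membered non-aromatic ring with 1 hetero atom) in place of a group of 6 heavy atoms (2 carbon, 1 nitrogen, 2 oxygen, 1 sulfur; no ring), on a saturated chain carbon bound to a double-bonded chain carbon). Going by the values given here, the only measured step of a number 25.6 percentage points lower from compound 1 to compound 2 (beyond the scatter) lies elsewhere in the molecule, so it shows only how large a single change can be. With compound 2 at 5.6% there is little room for a fall, so a modest rise is expected. The expected step (a number 11.4 percentage points higher from compound 2 to compound 3 (beyond the scatter)) is upward, though uncertain. Compound 3 is estimated at 17% with 2% to 45% as its range.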

Compound 3, percent growth inhibition at one concentration: 0%
For compound 3 the middle estimate is 17 percentage points above the measured one; measured number below the stated range.
By their numbers in this assay, from the lowest: compounds 3 and 2 (each within the scatter of the next); then compound 1.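

At this position, on a saturated chain carbon bound to a double-bonded chain carbon, placing the five-membered ring group of compound 3 where compound 2 carries (vinylsulfonyl)amino gives a number 5.6 percentage points lower from compound 2 to compound 3 (within the scatter) in this assay. The two groups therefore cannot be told apart here, although both compounds lie so near the bottom of the read-out that a further loss could hardly show. No measurement at hand gives a reason for this result.

Going by these compounds, it remains open whether an amine or a carboxylic acid at this place would move the number beyond the scatter. On these data alone, it is also open whether the two groups would still match alongside the 4-bromophenyl of compound 1.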